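The compounds below may be only part of what the source reports. "The series", "measured", "known", "first", "only" and "open" are said of these compounds alone.

Measured compounds:
- compound 1, `Cc1cccc(CSc2nc3cc(NC(=O)C4CC4)ccc3n2C(C)C)c1`: 6500 nM
- compound 2, `COc1ccc(C#N)cc1CSc1nc2cc(NC(=O)C3CC3)ccc2n1C(C)C`: 570 nM
- compound 3, `CCn1c(SCc2cc([N+](=O)[O-])ccc2OC)nc2cc(NC(=O)NC(C)(C)C)ccc21`: 42 nM

In an assay on isolated protein for inhibition of Gonadotropin-releasing hormone receptor (Homo sapiens) (on this read-out lower numbers stand for stronger inhibition and higher numbers for weaker inhibition), compound 3 gives the lowest number of the three. The nearest of the others is compound 2, and the furthest is compound 1, both with higher numbers and both beyond the scatter. Compound 4, `COc1ccc([N+](=O)[O-])cc1CSc1nc2cc(NC(=O)NC(C)(C)C)ccc2n1Cc1ccncc1`, differs from compound 3 in one place: pyridin-4-yl in place of methyl on a saturated chain carbon bound to an aromatic nitrogen, the same difference, cut one bond further out, reading ethyl to (pyridin-4-yl)methyl.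

For the measured compounds named here, the one step measured between compounds that differ in a single place, an 11-fold lower number from compound 1 to compound 2 (1.06 log units; beyond the scatter), concerns the aryl group on the saturated chain carbon bound to a sulfur, not the group on the aromatic nitrogen, so it does not bear on this change. Compounds 1 and 2 carry a different group on that nitrogen from compound 3, but they differ from compound 3 elsewhere as well, and their values alone show nothing about the nitrogen substituent. With no guide, the step is expected to be small, a 1.1-fold lower number from compound 3 to compound 4 (0.02 log units; within the scatter), in either direction. Compound 4 is therefore estimated at 40 nM, within 10 nM to 160 nM.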

Compound 4, half-maximal inhibitory concentration: 47 nM
For compound 4 the middle estimate is 1.2-fold (0.07 log units) below the measured one, and the stated range covers the measured number.
By their numbers in this assay, from the lowest: compounds 3 and 4 (each within the scatter of the next); then compound 2; then compound 1.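

In this assay, for the compounds shown here, the step of a 1.1-fold higher number from compound 3 to compound 4 (0.05 log units; within the scatter) gives the first reading at the saturated chain carbon bound to an aromatic nitrogen, and it shows that this position takes pyridin-4-yl in place of methyl with no change beyond the scatter. Going by these compounds alone, the only earlier step concerned the aryl group on the saturated chain carbon bound to a sulfur, so it said nothing about this place. Nothing measured here speaks to why the number holds when the ring enters.

From the compounds shown here alone, whether a plain phenyl, a pyridin-2-yl, or a chain ending in an amine or a carboxylic acid would read the same on that carbon stays open. So does whether the same change would hold alongside the cyclopropyl amide carried by compound 1 and compound 2.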